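The source may report more compounds than this note shows. Statements on the series, on what has been measured and on what is new or still open speak of the compounds shown alone.

Working notes on the series. Two members have been measured in a functional assay on HeLa cells (Homo sapiens) for cytotoxicity, read by MTT assay, with a stated time of 48 h; on this read-out lower numbers stand for stronger inhibition and higher numbers for weaker inhibition. Compound 1 `CCOC(=O)c1c(-c2c(Cl)c3ccccc3oc2=O)nn(-c2cccc(Cl)c2)c1C(=O)OCC` gives 40000 nM in this assay. Compound 2 `CCOC(=O)c1c(-c2c(Cl)c3cc(C)ccc3oc2=O)nn(-c2cccc(C)c2)c1C(=O)OCC` gives 115000 nM in this assay, the highest of the two numbers; its nearest neighbour is compound 1, and the gap between the two lies beyond the scatter, so compound 2 reads as the weaker of the pair. Going by the values given here, no single-change step between measured compounds exists, so the difference between compound 1 and compound 2 cannot be split into parts.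

Compound 3 `CCOC(=O)c1c(-c2c(Cl)c3cc(C)ccc3oc2=O)nn(-c2cccc(Cl)c2)c1C(=O)OCC` is not yet measured. It differs from compound 2 in one respect: chloro in place of methyl on an aromatic carbon. The same change, cut one bond further out, reads 3-methylphenyl to 3-chlorophenyl. Compound 3 thus shares its 3-chlorophenyl group with compound 1, which gives 40000 nM in this assay, and for that reason a step toward a lower number is expected, of the size a 1.8-fold lower number from compound 2 to compound 3 (0.25 log units; within the scatter), though possibly still within the scatter. The estimate for compound 3 in this assay is 65000 nM, with a range from 28000 nM to 150000 nM.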

Compound 3, half-maximal inhibitory concentration: 125000 nM
The estimate for compound 3 lay 1.9-fold (0.28 log units) below the measured number; the range from low to high includes it.
By their numbers in this assay, from the lowest: compound 1; then compounds 2 and 3 (each within the scatter of the next).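

In this assay, 3-methylphenyl and 3-chlorophenyl cannot be told apart in this setting (chloro in place of methyl on an aromatic carbon, meta to a large group, a 1.1-fold higher number from compound 2 to compound 3 (0.04 log units; within the scatter)), so sharing the 3-chlorophenyl group with compound 1 does not place compound 3 with it. With that group held constant, the step beyond the scatter is the other single change, methyl in place of hydrogen on an aromatic carbon (a 3.1-fold higher number from compound 1 to compound 3 (0.49 log units; beyond the scatter)), although its size is modest. Nothing at hand offers an explanation for either step.

From the compounds shown here alone, whether methyl and chloro also read alike at this position in a compound lacking the methyl that separates compound 3 from compound 1 remains open. The compounds shown also leave open how a methoxy group, an amine or a carboxylic acid would read at this position.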